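The compounds below may be only part of what the source reports. "The series", "measured", "known", "first", "only" and "open" are said of these compounds alone.

In an assay on V79MZh cells for inhibition of cytochrome P450 11B2, mitochondrial (Homo sapiens), with a stated time of 30 min (a higher number here means a weaker inhibitor, a lower number a stronger inhibitor), the three measured compounds stand as follows:
compound 1 `O=c1c(Cn2ccnc2)coc2cc(F)ccc12` gives 214 nM;
compound 2 `O=c1c(Cc2c[nH]cn2)coc2ccccc12` gives 121 nM;
compound 3 `O=c1c(Cc2cccnc2)coc2ccccc12` gives > 10000 nM, a limit of this assay and not a number.

Compound 3 thus sits at the limit of > 10000 nM in this assay, at which 1 of the 3 values shown sits, apart from the two numbered values. Going by the values given here, the one measured single change, an at least 82-fold higher number from compound 2 to compound 3 (1.91 log units; beyond the scatter), concerns the heterocycle, not the fused ring. Compound 4 `O=c1c(Cc2cccnc2)coc2cc(F)ccc12` differs from compound 3 by fluoro in place of hydrogen on an aromatic carbon. Among the compounds with values here, no measured step isolates such a fluoro exchange; compound 1 and compound 2 differ in two places at once, so their values are not read as a step. The analyst therefore expects no step beyond the scatter, a step that the limit leaves unreadable from compound 3 to compound 4, and estimates compound 4 at 12000 nM, between 4000 nM and 40000 nM, most probably reported again only as a limit.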

Compound 4, half-maximal inhibitory concentration: > 10000 nM
Compound 4: no number, only a limit (the forecaster's own chance of this, stated with the estimate: 85%); the middle value lies beyond the limit too.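

Compound 4 gives > 10000 nM in this assay, a limit of the assay and not a number. Pyridin-3-yl in place of 1H-imidazol-1-yl on the fluoro-bearing core gives an at least 46-fold higher number from compound 1 to compound 4 (1.66 log units; beyond the scatter), so pyridin-3-yl goes with a large rise with the fluoro present as well as without it. The fluoro exchange itself cannot be read, as compound 3 and compound 4 both stand at a limit: the limit of > 10000 nM in this assay, at which 2 of the 4 values shown sit.

As far as these compounds go, what fluoro does in a compound with a measurable value stays open. So does whether chloro or methoxy on that aromatic carbon, or a longer chain carrying the pyridin-3-yl, would give a number.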